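This account rests on a few compounds, and the source may have more. Where it says the series, first, only, none or still open, it means among the compounds named here.

Compound 1 `CCCN(CC[C@H]1CC[C@H](NC(=O)/C=C/c2cccc(F)c2)CC1)[C@H]1CCc2nc(N)sc2C1` gives 9.9 nM in an assay on brain for displacement of a labelled ligand from D(3) dopamine receptor (Rattus norvegicus); on this read-out higher numbers stand for weaker inhibition and lower numbers for stronger inhibition. Compound 2 `CCCN(CC[C@H]1CC[C@H](NC(=O)/C=C/c2ccc(Cl)cc2)CC1)[C@H]1CCc2nc(N)sc2C1` gives 2.5 nM. Compound 3 `CCCN(CC[C@H]1CC[C@H](NC(=O)/C=C/c2ccc(OC)cc2)CC1)[C@H]1CCc2nc(N)sc2C1` gives 6.7 nM.

Compound 3 stands second highest of the three numbers; its nearest neighbour is compound 1, and the gap between them is within the scatter, while a 2.7-fold higher number from compound 2 to compound 3 (0.43 log units; beyond the scatter) is beyond it. Compound 4 `CCCN(CC[C@H]1CC[C@H](NC(=O)/C=C/c2ccccc2OC)CC1)[C@H]1CCc2nc(N)sc2C1` differs from compound 3 by 2-methoxyphenyl in place of 4-methoxyphenyl on a double-bonded chain carbon bound to a double-bonded chain carbon. Going by the values given here, no measured step moves a methoxy around the ring; the only aryl changes known are a 4.0-fold lower number from compound 1 to compound 2 (0.60 log units; beyond the scatter) and a 1.5-fold lower number from compound 1 to compound 3 (0.17 log units; within the scatter), both between different substituents rather than positions of one. A modest step is therefore expected, leaning toward a higher number, a 2.2-fold higher number from compound 3 to compound 4 (0.35 log units; beyond the scatter), though the data give no firm anchor. Compound 4 is estimated at 15 nM, between 5 nM and 45 nM.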

Compound 4, inhibition constant: 8.1 nM
For compound 4 the middle estimate is 1.9-fold (0.27 log units) above the measured one, and the stated range covers the measured number.
By their numbers in this assay, from the lowest: compound 2; then compounds 3, 4 and 1 (each within the scatter of the next).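

Moving the methoxy group gives the first look at a change of position for one substituent, and in this assay 2-methoxyphenyl in place of 4-methoxyphenyl stays within the scatter (a 1.2-fold higher number from compound 3 to compound 4 (0.08 log units; within the scatter)). Compound 4 also stays within the scatter of the 3-fluorophenyl compound (a 1.2-fold lower number from compound 1 to compound 4 (0.09 log units; within the scatter)), while the 4-chlorophenyl compound remains apart (a 3.2-fold higher number from compound 2 to compound 4 (0.51 log units; beyond the scatter)). No evidence at hand explains these results. The compounds shown leave open whether 3-methoxyphenyl would read like its two isomers, whether 2-chlorophenyl would match 4-chlorophenyl, and how an amine or carboxylic acid on the aromatic ring would read.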